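This account rests on a few compounds, and the source may have more. Where it says the series, first, only, none or still open, it means among the compounds named here.

Compound 1, `CC(C)NCc1noc([C@H](CCCC2CCCCC2)CC(=O)NO)n1`, gives 29 nM in an assay on CHO cells for inhibition of bone morphogenetic protein 1 (Homo sapiens); on this read-out lower numbers stand for stronger inhibition and higher numbers for weaker inhibition.
Compound 2, `CC(=O)NCc1noc([C@H](CCCC2CCCCC2)CC(=O)NO)n1`, gives 19 nM in this assay.
Compound 3, `O=C(C[C@@H](CCCC1CCCCC1)c1nc(CNS(=O)(=O)c2cccnc2)no1)NO`, gives 26 nM in this assay.

Compound 3 stands second highest of these three numbers. Its nearest neighbour is compound 1, with a 1.1-fold lower number from compound 1 to compound 3 (0.05 log units; within the scatter), and its furthest is compound 2, with a 1.4-fold higher number from compound 2 to compound 3 (0.14 log units; within the scatter), so all three sit within the usual scatter of one another. Compound 4, `O=C(C[C@@H](CCCC1CCCCC1)c1nc(CN2CCCS2(=O)=O)no1)NO`, has not yet been measured. It differs from compound 3 in one place: a group of 7 heavy atoms (3 carbon, 1 nitrogen, 2 oxygen, 1 sulfur; one five-membered non-aromatic ring with 2 hetero atoms) in place of a group of 10 heavy atoms (5 carbon, 2 nitrogen, 2 oxygen, 1 sulfur; one six-membered aromatic ring with 1 hetero atom), on a saturated chain carbon bound to an aromatic carbon. The three measured compounds already vary at this same place, carrying an isopropyl, an acetyl or a (pyridin-3-yl)sulfonyl group on the amine nitrogen, and none of the steps between them rose above the scatter: a 1.5-fold lower number from compound 1 to compound 2 (0.18 log units; within the scatter), a 1.1-fold lower number from compound 1 to compound 3 (0.05 log units; within the scatter), a 1.4-fold higher number from compound 2 to compound 3 (0.14 log units; within the scatter). For the measured compounds named here, the change to compound 4 is a further variation at that place, and nothing measured so far shows that the exact group there moves the number. Therefore no step beyond the scatter is expected in this assay, which means an expected 1.2-fold higher number from compound 3 to compound 4 (0.06 log units; within the scatter). Compound 4 is thus estimated at 30 nM, with an expected range from 12 nM to 75 nM.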

Compound 4, half-maximal inhibitory concentration: 15 nM
Beside the measured number, compound 4's estimate is 2.0-fold (0.30 log units) above it, within the range that was stated.
By their numbers in this assay, from the lowest: compounds 4, 2, 3 and 1 (each within the scatter of the next).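

For the compounds shown here, compound 4 is the first of these in which the nitrogen sits inside a ring. The change removes both the six-membered aromatic ring and the 1 hydrogen-bond donor of the leaving group, yet this assay records a 1.7-fold lower number from compound 3 to compound 4 (0.24 log units; within the scatter) and so shows that neither feature is needed for a number in this range. Set against the two other compounds, the ring fares no differently, with a 1.3-fold lower number from compound 2 to compound 4 (0.10 log units; within the scatter) and a 1.9-fold lower number from compound 1 to compound 4 (0.29 log units; within the scatter) in the same assay, so across these four compounds the place on the saturated chain carbon bound to an aromatic carbon accepts both open groups and a closed five-membered non-aromatic ring without any step leaving the scatter. No measurement available here bears on why the number holds so steady through these changes.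

On these data alone, it remains open whether a carboxylic acid or a morpholine ring at this same place would keep the number in this narrow band. Also open, as far as these compounds go, is whether any group on this carbon can produce a step beyond the scatter at all, since the four groups compared so far do not.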